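A tert-Butyl Group on the Benzyl Ether of Compound 1

A few compounds are considered here, and "the series" means these few. Any claim that something is new, unique, unknown or untested is made for them only; others in the source may bear on it.

Compound 1 `CCC1(Cc2ccccc2)OS(=O)(=O)C=C1OCc1ccccc1` gives 200000 nM in an ADME assay on HEL cells (Homo sapiens) for cytotoxicity, with a stated time of 3 days; a lower number here means that less compound is tolerated, a higher number that more compound is tolerated.
Compound 2 `CCC1(Cc2ccccc2)OS(=O)(=O)C=C1OC(=O)c1ccccc1` reaches only a limit of the assay, > 200000 nM.
Compound 3 `CC(C)C1(Cc2ccccc2)OS(=O)(=O)C=C1OCc1ccccc1` gives 200000 nM in this assay.

The three measured compounds share one core and differ only at its edges. Compound 1 stands level with compound 3: the step of no change at the digits printed from compound 1 to compound 3 (within the scatter) is within the scatter. For compound 2 the reading is a limit, not a number (the limit of > 200000 nM in this assay, at which 1 of the 3 values shown sits). The step of a number no lower from compound 1 to compound 2 (the limit leaves the size open) is therefore of unreadable size.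

Compound 4 `CCC1(Cc2ccccc2)OS(=O)(=O)C=C1OCc1ccc(C(C)(C)C)cc1` is the next compound. The change from compound 1 is tert-butyl in place of hydrogen on an aromatic carbon. For the measured compounds named here, no measured step touches the benzyl ring itself; the two steps that exist, a benzoyl for a benzyl and a methyl for a hydrogen, both left the value unchanged or at the limit. From that, a step of no more than the scatter is expected in this assay, in no firm direction. Compound 4 is expected to give 180000 nM, between 60000 nM and 200000 nM, a step of a 1.1-fold lower number from compound 1 to compound 4 (0.05 log units; within the scatter). The measured value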

Compound 4, half-maximal cytotoxic concentration: 200000 nM
Estimate against measurement, compound 4: 1.1-fold (0.05 log units) below; low and high end bracket the measured number.
By their numbers in this assay, from the lowest: compounds 1, 3 and 4 (each within the scatter of the next).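

For the compounds shown here, this is the first measured change on the benzyl ring itself, on an aromatic carbon of that six-membered ring. In this assay, tert-butyl in place of hydrogen brings no change at the digits printed from compound 1 to compound 4 (within the scatter). So a group of 4 carbon atoms at this place on the ring leaves the tolerated concentration where compound 1 and compound 3 already stand, and the ring position is shown to accept a large addition without a readable shift.

Whether an amine or a carboxylic acid at the same place would also leave the reading unmoved stays open, since tert-butyl is the only group shown on this ring. The reading for compound 2 remains a limit and not a number, so its step cannot be read: the limit of > 200000 nM in this assay, at which 1 of the 4 values shown sits.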